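The source may hold more compounds than are shown below. What is called first, only, known or untested is meant among the compounds shown, and "the series" means these compounds.

Compound 1, `Cc1nn(-c2ncnc3nc[nH]c23)c2c1C(OCc1ccccc1Cl)CC(=O)N2`, gives 47 nM.
Compound 2, `Cc1nn(-c2ncnc3nc[nH]c23)c2c1C(OCCn1cccn1)CC(=O)N2`, gives 2270 nM.
Compound 3, `CCCCCCCCOC1CC(=O)Nc2c1c(C)nn2-c1ncnc2nc[nH]c12`, gives 388 nM.

All three values come from a functional assay on HEK293 cells for agonist activity at G-protein coupled receptor 39 (Homo sapiens), read by scintillation proximity assay and inositol phosphate accumulation, with a stated time of 75 min; on this read-out higher numbers stand for an effect only at larger amounts of compound and lower numbers for an effect already at smaller amounts. Among them compound 3 stands second highest; its nearest neighbour is separated from it by the step of a 5.9-fold lower number from compound 2 to compound 3 (0.77 log units; beyond the scatter), and its furthest by the step of an 8.3-fold higher number from compound 1 to compound 3 (0.92 log units; beyond the scatter).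

Compound 4, `Cc1nn(-c2ncnc3nc[nH]c23)c2c1C(C(=O)N(C)c1ccccc1)CC(=O)N2`, has not yet been measured. It differs from compound 3 in one place: methyl(phenyl)carbamoyl in place of octyloxy on a saturated ring carbon.

Among the compounds with values here, none of the measured steps covers such a change. Each of them, a 48-fold higher number from compound 1 to compound 2 (1.68 log units; beyond the scatter), an 8.3-fold higher number from compound 1 to compound 3 (0.92 log units; beyond the scatter) and a 5.9-fold lower number from compound 2 to compound 3 (0.77 log units; beyond the scatter), swaps only the group carried on the chain beyond the oxygen, while the oxygen itself stays attached to the saturated ring carbon. In compound 4 that oxygen is gone and an amide-type group takes its place, so the measured steps give no direct guide, even though each of them shifted the number beyond the scatter. Without a guide, the expected step of a 1.0-fold higher number from compound 3 to compound 4 (0.01 log units; within the scatter) is set at none beyond the scatter, with a wide range to reflect the uncertainty.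

For compound 4 the expected value in this assay is therefore 400 nM, with an estimated range from 50 nM to 3000 nM.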

Compound 4, half-maximal effective concentration: 5220 nM
Compound 4: middle estimate off by 13-fold (1.12 log units), on the low side, outside the stated range (above it).
By their numbers in this assay, from the lowest: compound 1; then compound 3; then compound 2; then compound 4.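

In this assay, putting methyl(phenyl)carbamoyl on the saturated ring carbon gives a higher number than octyloxy (a 13-fold higher number from compound 3 to compound 4 (1.13 log units; beyond the scatter)), 2-(1H-pyrazol-1-yl)ethoxy (a 2.3-fold higher number from compound 2 to compound 4 (0.36 log units; beyond the scatter)) and (2-chlorobenzyl)oxy (a 110-fold higher number from compound 1 to compound 4 (2.05 log units; beyond the scatter)). Within the data shown here, compound 4 therefore has the highest number of the four, showing that this position also responds when the oxygen link is replaced, whereas the earlier steps changed only the chain beyond that oxygen. Both compound 1 and compound 4 carry a six-membered aromatic ring of carbon only in the changed group, yet they are the furthest apart, so having such a ring in this group does not by itself give a low number, and no measurement here explains the shift.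

This change replaces the oxygen link and the group beyond it together, so the compounds shown cannot tell which of the two matters more. An amide without the methyl group, or a 2-chlorobenzyl group joined through an amine nitrogen on the same ring carbon, would help to separate these two parts of the change.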